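The source may report more compounds than this note shows. Statements on the series, on what has been measured and on what is new or still open speak of the compounds shown alone.

Compound 1 `O=C(Nc1ccc(Cl)cc1)N[C@H]1CC[C@H](Oc2ccc(F)cc2)CC1`: in a functional assay on CRL2813 cells (Homo sapiens) for cytotoxicity, read by sulforhodamine B assay, with a stated time of 5 days (on this read-out lower numbers stand for stronger inhibition and higher numbers for weaker inhibition), compound 1 gives > 20000 nM, which is a limit of the assay rather than a number.
Compound 2 `O=C(Nc1ccc([N+](=O)[O-])cc1)N[C@H]1CC[C@H](Oc2ccc(F)cc2)CC1`: in this assay compound 2 gives 2300 nM.
Compound 3 `COc1cccc(NC(=O)N[C@H]2CC[C@H](Oc3ccc(F)cc3)CC2)c1`: in this assay compound 3 gives 14000 nM.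

Of the two numbers shown, compound 3 has the highest: the step of a 6.1-fold higher number from compound 2 to compound 3 (0.78 log units; beyond the scatter) is beyond the scatter, while an at least 1.4-fold lower number from compound 1 to compound 3 (0.15 log units; that floor lies within the scatter) is only a floor that lies within it. Compound 4 `Cc1cccc(NC(=O)N[C@H]2CC[C@H](Oc3ccc(F)cc3)CC2)c1` differs from compound 3 by methyl in place of methoxy on an aromatic carbon. For the measured compounds named here, no measured step swaps methyl for methoxy; the steps that touch compound 3 compare its 3-methoxyphenyl with 4-nitrophenyl and 4-chlorophenyl groups, so they give no direction for this change. A step of no size beyond the scatter is therefore expected, no change at the digits printed from compound 3 to compound 4 (within the scatter). Compound 4 is expected to give about 14000 nM in this assay, between 5000 nM and 40000 nM.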

Compound 4, half-maximal inhibitory concentration: 14400 nM
Beside the measured number, compound 4's estimate is 1.0-fold (0.01 log units) below it, and the stated range covers the measured number.
By their numbers in this assay, from the lowest: compound 2; then compounds 3 and 4 (each within the scatter of the next). At a limit, above all of these: compound 1.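

In this assay, methyl in place of methoxy at this position gives a 1.0-fold higher number from compound 3 to compound 4 (0.01 log units; within the scatter), so it makes no readable difference. The 3-methylphenyl group therefore sits as far from 4-nitrophenyl as 3-methoxyphenyl does, with a 6.3-fold higher number from compound 2 to compound 4 (0.80 log units; beyond the scatter). The step against 4-chlorophenyl reads an at least 1.3-fold lower number from compound 1 to compound 4 (0.14 log units; that floor lies within the scatter), and this is only a floor, because compound 1 carries only a limit: the limit of > 20000 nM in this assay, at which 1 of the 4 values shown sits.

From the compounds shown here alone, whether an amine or a carboxylic acid at this position would shift the number remains open. Also open, going by these compounds, is whether the gap to 4-nitrophenyl follows the group itself or where it sits on the ring, since that step changes both.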